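The source may report more compounds than this note shows. Statements on the series, on what has been measured and on what is new or still open speak of the compounds shown alone.

Three compounds share one core and differ only in the group on the amide-type nitrogen. Compound 1 `COc1ccc2c(=O)c(/C=C/C(=O)Nc3cc(C)ccc3C)coc2c1` gives 1100000 nM in an ADME assay on HepG2 2.2.15 cells (Homo sapiens) for cytotoxicity, read by MTT assay, with stated times of 48 h and 9 days (on this read-out lower numbers stand for higher toxicity in this test and higher numbers for lower toxicity in this test), and compound 2 `COc1cccc(NC(=O)/C=C/c2coc3cc(OC)ccc3c2=O)c1` gives 1130000 nM; the move from one to the other is a 1.0-fold higher number from compound 1 to compound 2 (0.01 log units; within the scatter). Compound 3 `COc1ccc(CNC(=O)/C=C/c2coc3cc(OC)ccc3c2=O)cc1` gives 43000 nM, the lowest of the three numbers, so it is the most toxic of the set: the change is a 26-fold lower number from compound 1 to compound 3 (1.41 log units; beyond the scatter) and a 26-fold lower number from compound 2 to compound 3 (1.42 log units; beyond the scatter).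

Compound 4 `COc1ccc2c(=O)c(/C=C/C(=O)Nc3ccccc3OC)coc2c1` carries the change (2-methoxyphenyl in place of 4-methoxybenzyl on an amide-type nitrogen). This runs opposite to the two large steps just described, in which 4-methoxybenzyl entered in place of a methoxyphenyl or dimethylphenyl group and the number fell steeply. The reverse exchange is therefore expected to raise the number back toward the values of compound 1 and compound 2, an estimated step of a 21-fold higher number from compound 3 to compound 4 (1.32 log units; beyond the scatter). For compound 4 the estimate in this assay is 900000 nM, with a range from 300000 nM to 2000000 nM.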

Compound 4, half-maximal cytotoxic concentration: 1050000 nM
The estimate for compound 4 lay 1.2-fold (0.07 log units) below the measured number, within the range that was stated.
By their numbers in this assay, from the lowest: compound 3; then compounds 4, 1 and 2 (each within the scatter of the next).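

This result shows that the sharp drop belongs to compound 3 alone: swapping its 4-methoxybenzyl group for 2-methoxyphenyl on the amide-type nitrogen restores a high number in this assay (a 24-fold higher number from compound 3 to compound 4 (1.39 log units; beyond the scatter)). The three compounds with a phenyl group on that nitrogen cannot be told apart, whether 2-methoxyphenyl is compared with 3-methoxyphenyl (a 1.1-fold lower number from compound 2 to compound 4 (0.03 log units; within the scatter)) or with 2,5-dimethylphenyl (a 1.0-fold lower number from compound 1 to compound 4 (0.02 log units; within the scatter)), so these changes to the ring substituents leave the number in place. No available evidence explains why 4-methoxybenzyl stands apart.

On these data alone, it remains open whether the low number needs the methoxy group of 4-methoxybenzyl or would also appear with a plain benzyl group or a longer chain such as 2-phenylethyl. As far as these compounds go, the effect of an amine or a carboxylic acid on the phenyl ring also remains open.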